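Dimethylamino for Fluoro on the Aryl Ring

The compounds below may be only part of what the source reports. "The series", "measured", "known", "first", "only" and "open" are said of these compounds alone.

Measured compounds in an assay for binding affinity to adenosine receptor A1 (Bos taurus); a lower number here means a stronger inhibitor, a higher number a weaker inhibitor:
Compound 1 `Cn1c(=O)c2nc(-c3cccc(F)c3)[nH]c2n(C)c1=O`: 4 nM
Compound 2 `CN(C)c1ccc(-c2nc3c(=O)n(C)c(=O)n(C)c3[nH]2)cc1`: 1.8 nM
Compound 3 `Cn1c(=O)c2nc(-c3ccc(I)cc3)[nH]c2n(C)c1=O`: 1.3 nM

Compound 1 carries the highest number of the three. Compound 2 sits nearest to it, a gap beyond the scatter, and compound 3 lies furthest, also beyond the scatter. Compound 4 `CN(C)c1cccc(-c2nc3c(=O)n(C)c(=O)n(C)c3[nH]2)c1` differs from compound 1 by dimethylamino in place of fluoro on an aromatic carbon, with the new group placed meta to a large group on the six-membered carbon ring.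

For the measured compounds named here, only one measured step touches on this change: a 1.4-fold lower number from compound 2 to compound 3 (0.14 log units; within the scatter). It shows that dimethylamino and iodo on the same ring position give numbers within the scatter of each other, so a dimethylamino group is at least compatible with a low number in this assay. It does not, however, compare dimethylamino with fluoro, nor at the position where compound 4 carries it, so the bearing is indirect.

Given that compound 2 with dimethylamino gives 1.8 nM while compound 1 gives 4 nM, a modest move to a lower number is expected for compound 4, around a 1.6-fold lower number from compound 1 to compound 4 (0.20 log units; within the scatter). The estimate for compound 4 is 2.5 nM, with a range from 1 nM to 7 nM.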

Compound 4, half-maximal inhibitory concentration: 80 nM
Estimate against measurement, compound 4: 32-fold (1.51 log units) below; measured number above the stated range.
By their numbers in this assay, from the lowest: compounds 3 and 2 (each within the scatter of the next); then compound 1; then compound 4.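

In this assay, for the compounds shown here, putting dimethylamino in place of fluoro on an aromatic carbon, meta to a large group, brings a 20-fold higher number from compound 1 to compound 4 (1.30 log units; beyond the scatter), so this exchange at this position carries a large penalty that the earlier compounds gave no sign of. Compound 2, which holds the same dimethylamino group elsewhere on the ring, gives 1.8 nM, whereas compound 4 gives 80 nM, which shows that the low number of compound 2 does not carry over and that the group's place on the ring matters in this series. No measurement shown here explains why the number rises at this position.

The compounds shown leave open whether the rise belongs to dimethylamino alone or would also appear with other groups in the same place, such as a primary amine, a methoxy group or a methyl group. On these data alone, they also leave open how a hydrogen at this position would compare with fluoro, so the part played by fluoro in the number of compound 1 remains unknown.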